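The source may report more compounds than this note shows. Statements on the series, on what has been measured and on what is new or still open speak of the compounds shown alone.

Of the compounds shown here, two have been measured so far in a functional assay on KB cells (Homo sapiens) for inhibition, read by MTT assay, with a stated time of 24 h, tested at 100 ug/mL; on this read-out lower numbers stand for less inhibition of growth and higher numbers for more inhibition of growth at the one concentration tested. Compound 1 (`O=C(CCCCC1CCSS1)Nc1ccc(Br)cn1`) gives 42.3%, and compound 2 (`O=C(CCCCC(S)CCS)Nc1ccc(Cl)cn1`) gives 76.6%. Compound 2 therefore stands higher of the two, by a gap beyond the usual scatter of such measurements. These two compounds differ in more than one place, so their gap cannot be traced to any single structural change and offers no guide to the size of the next step.

Compound 3 (`O=C(CCCCC(S)CCS)Nc1ccc(Br)cn1`) has not yet been measured. It departs from compound 2 in one place, with bromo in place of chloro on an aromatic carbon. Among the measured compounds shown here, no measured pair shows what this swap does, so the working expectation in this assay is no change beyond the scatter, starting from compound 2 at 76.6%. The expected change is small, and the estimated a number 2.6 percentage points lower from compound 2 to compound 3 (within the scatter) stays within that scatter. For compound 3 the estimated value is 74%, with an expected range of 60% to 88%.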

Compound 3, percent growth inhibition at one concentration: 59.2%
For compound 3 the middle estimate is 14.8 percentage points above the measured one; the measured number lies below the stated range.
By their numbers in this assay, from the lowest: compound 1; then compound 3; then compound 2.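

In this assay, the aromatic carbon two atoms from the ring nitrogen and para to a large group proves sensitive to which halogen it carries, with bromo in place of chloro (a number 17.4 percentage points lower from compound 2 to compound 3 (beyond the scatter)). Among the compounds shown here, this is the first reading of a change in this one place, and it shows that exchanging one heavy atom for another, with no ring, hydrogen-bond donor, acceptor or net charge entering or leaving, can move the number beyond the scatter. The far end of the molecule matters too: on the saturated chain carbon, four bonds along from the carbonyl carbon, a group of 5 heavy atoms with no ring takes the place of one with the same atom count held in a five-membered non-aromatic ring with 2 hetero atoms (a number 16.9 percentage points higher from compound 1 to compound 3 (beyond the scatter)).

No measurement at hand accounts for either step. Going by these compounds, it remains open whether bromo and chloro would differ in the same way on the ring-bearing form of compound 1, and how fluoro or methoxy at the aromatic position, or a longer chain, would read here.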